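Compound 3 to compound 4: fluoro in place of methoxy

The source may hold more compounds than are shown below. What is called first, only, known or untested is meant among the compounds shown, and "the series" means these compounds.

Compound 1 `COc1ccc(/C=C/C[C@@H]2C[C@@H]([C@@H](OC(C)=O)c3ccc(OC)c(OC)c3)CO[C@H]2c2ccc(OC)c(OC)c2)cc1OC` reads > 100000 nM in a functional assay on HeLa cells (Homo sapiens) for cytotoxicity, read by WST assay, with a stated time of 48 h (on this read-out higher numbers stand for weaker inhibition and lower numbers for stronger inhibition), as a limit, not a number. Compound 2 `COc1ccc(/C=C/C[C@H]2C[C@@H]([C@@H](O)c3ccccc3)CO[C@@H]2c2ccc(OC)c(OC)c2)cc1OC` gives 15500 nM and compound 3 `COc1ccc(/C=C/C[C@H]2C[C@@H]([C@@H](O)c3ccccc3)CO[C@@H]2c2ccccc2)cc1` gives 8300 nM in this assay here, two values within the scatter of each other. Within the data shown here, compound 3 therefore stands level with compound 2, and these are the only two numbers available. The next structure, compound 4 `O[C@@H](c1ccccc1)[C@H]1CO[C@H](c2ccccc2)[C@@H](C/C=C/c2ccc(F)cc2)C1`, has fluoro in place of methoxy on an aromatic carbon, para to a large group (fluoro in place of methoxy on an aromatic carbon). Among the measured compounds shown here, no measured step covers this change. No shift beyond the scatter is expected in this assay for it, and the estimated step is small (a 1.0-fold lower number from compound 3 to compound 4 (0.02 log units; within the scatter)). For compound 4 the expected value is 8000 nM with an estimated range from 3000 nM to 25000 nM as the working figure.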

Compound 4, half-maximal inhibitory concentration: 8340 nM
Estimate against measurement, compound 4: 1.0-fold (0.02 log units) below; the range from low to high includes it.
By their numbers in this assay, from the lowest: compounds 3, 4 and 2 (each within the scatter of the next). At a limit, above all of these: compound 1.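

In this assay the series gets its first comparison of compounds differing in one place, and it reads a 1.0-fold higher number from compound 3 to compound 4 (0.00 log units; within the scatter). 4-Methoxyphenyl to 4-fluorophenyl therefore leaves the read-out unmoved, so this aromatic carbon, para to a large group, carries either methoxy or fluoro with no shift beyond the scatter. Nothing at hand accounts for this flat step.

Only these two substituents have been compared at this position, so its wider tolerance remains undefined. As far as these compounds go, whether an amine or a carboxylic acid here would shift the number stays open.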